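Methylating the Ring Amide Nitrogen in Two Indole Series

This account rests on a few compounds, and the source may have more. Where it says the series, first, only, none or still open, it means among the compounds named here.

Compound 1 `COc1cc2c(cc1C)NC(=O)/C2=C/c1c(Cl)n(C)c2cc(C)c(OC)cc12` and compound 2 `COc1cc2c(cc1C)N(C)C(=O)/C2=C/c1c(Cl)n(C)c2cc(C)c(OC)cc12` share one core. In a functional assay on cells (Cancer cell lines, Homo sapiens) for inhibition, with a stated time of 48 h (a lower number here means a stronger inhibitor of growth, a higher number a weaker inhibitor of growth), compound 1 gives 18600 nM, while compound 2 gives 6760 nM. The change between them is methyl in place of hydrogen on an amide-type nitrogen in a ring, and it made a 2.8-fold lower number from compound 1 to compound 2 (0.44 log units; beyond the scatter). Compound 3 `CN(C)c1ccc2[nH]c(Cl)c(/C=C3/C(=O)Nc4ccc(O)cc43)c2c1` rests on a different core; the difference between the two cores is not broken down here. In this assay compound 3 gives 2880 nM, the lowest of the three measured numbers. Compound 4 `CN(C)c1ccc2[nH]c(Cl)c(/C=C3/C(=O)N(C)c4ccc(O)cc43)c2c1` has not yet been measured. It differs from compound 3 by methyl in place of hydrogen on an amide-type nitrogen in a ring, the same change seen between the first two compounds, at a place described in the same words. Among the compounds with values here, only one earlier instance is known, so the expectation is tentative. The study expects a step of a 2.4-fold lower number from compound 3 to compound 4 (0.38 log units; beyond the scatter), resting on a 2.8-fold lower number from compound 1 to compound 2 (0.44 log units; beyond the scatter) in the same assay. Compound 4 is therefore estimated at 1200 nM in this assay, with a range from 500 nM to 3000 nM.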

Compound 4, concentration for 50% growth inhibition: 3800 nM
Compound 4: middle estimate off by 3.2-fold (0.50 log units), on the low side; the measured number lies above the stated range.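

On the core of compound 3, methyl in place of hydrogen on the amide-type nitrogen in a ring gave a 1.3-fold higher number from compound 3 to compound 4 (0.12 log units; within the scatter) in this assay, so the lower number seen on the core of compound 1 did not carry over. The two cores answer differently to the same change: the same change on two cores in this assay, a 2.8-fold lower number (0.44 log units; beyond the scatter) from compound 1 to compound 2 and a 1.3-fold higher number (0.12 log units; within the scatter) from compound 3 to compound 4, 3.6-fold (0.56 log units) apart, beyond the scatter of two such steps. This shows that the step cannot simply be transferred from one of these cores to the other, but with one pair on each core it does not show which feature of the cores sets the difference.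

The compounds shown leave open how the change would behave on any further core. They also leave open whether ethyl, a longer chain or a chain ending in an amine on that nitrogen would shift the number on either core.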